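A few compounds are considered here, and "the series" means these few. Any claim that something is new, unique, unknown or untested is made for them only; others in the source may bear on it.

Measured so far in an ADME assay on the whole organism (Mus musculus, strain C57BL/6) for pharmacokinetics, read by LC-MS, with a stated time of 24 h, at a dose of 2 mg/kg by the intravenous route (a higher number here means faster removal of the compound, a lower number slower removal), are two compounds:

- Compound 1 `Nc1ncn(Cc2c(Cl)cccc2Cl)c2ncnc1-2` gives 5.8 mL/min/kg here
- Compound 2 `Nc1ncn(Cc2c(Cl)cncc2Cl)c2ncnc1-2` gives 18 mL/min/kg here

Of these two numbers, compound 2 holds the higher, and compound 1 sits lower by more than the usual scatter of repeated measurements. Two compounds make no trend, and neither shows what a new group at this place would do.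

Compound 3 `Cc1ccccc1-c1nc2c(N)ncn(Cc3c(Cl)cncc3Cl)c-2n1` differs from compound 2 at a single site. It carries 2-methylphenyl in place of hydrogen on an aromatic carbon of a five-membered aromatic ring with 2 nitrogen, part of a fused or bridged system of two rings, between two ring nitrogen atoms (see (2-methylphenyl in place of hydrogen on an aromatic carbon)). Going by the values given here, no measured pair contains such a change, so the step in this assay can only be judged loosely. Starting from compound 2 at 18 mL/min/kg as the anchor, a moderate move toward faster removal is expected, one that may not clear the scatter. The estimated move is a 1.4-fold higher number from compound 2 to compound 3 (0.16 log units; within the scatter) and it remains uncertain. For compound 3 the estimated clearance is 26 mL/min/kg, with an expected range from 11 mL/min/kg to 60 mL/min/kg on repeated measurement.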

Compound 3, clearance: 103 mL/min/kg
The estimate for compound 3 lay 4.0-fold (0.60 log units) below the measured number; measured number above the stated range.
By their numbers in this assay, from the lowest: compound 1; then compound 2; then compound 3.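

The aromatic carbon between two ring nitrogen atoms proves to be a place where a substituent can change the outcome in this assay: 2-methylphenyl in place of hydrogen gives a 5.7-fold higher number from compound 2 to compound 3 (0.76 log units; beyond the scatter). With this one change, compound 3 reaches 103 mL/min/kg, the highest of the three numbers, so removal of the compound is sensitive to what stands at this site, at least for this large group, which adds one six-membered aromatic ring of carbon only and no hydrogen-bond donors or acceptors. No independent measurement is available to explain the rise.

With only one substituent shown at this place, it remains open whether the step belongs to the phenyl ring as a whole or to its methyl group, and whether plain phenyl, a lone methyl, or a phenyl ring carrying an amine or a carboxylic acid would move the number as far. Going by these compounds, it also remains open whether 2-methylphenyl would produce a step of similar size on the core of compound 1, whose other ring has carbon where compound 2 has nitrogen.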